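The source may hold more compounds than are shown below. What is called first, only, known or untested is meant among the compounds shown, and "the series" means these compounds.

Compound 1 `CN1C/C(=C\c2cccc([N+](=O)[O-])c2)C(=O)/C(=C/c2ccccc2F)C1`: 1010 nM
Compound 2 `COc1cc(/C=C2\CN(C)C/C(=C\c3ccc(Br)cc3)C2=O)cc(OC)c1`: 4270 nM
Compound 3 `COc1cc(/C=C2\CN(C)C/C(=C\c3ccc(F)cc3)C2=O)cc(OC)c1OC`: 6130 nM

In a functional assay on THP-1 cells (Homo sapiens) for cytotoxicity, read by MTT assay, with a stated time of 24 h (on this read-out higher numbers stand for weaker inhibition and lower numbers for stronger inhibition), compound 1 gives 1010 nM, the lowest of the three numbers and so the strongest inhibition here. Compound 2 at 4270 nM lies higher, beyond the usual scatter, and so does compound 3 at 6130 nM.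

The next compound to be tested is compound 4 `CN1C/C(=C\c2cccc(Br)c2)C(=O)/C(=C/c2cccc([N+](=O)[O-])c2)C1`. It differs from compound 1 in one place: 3-bromophenyl in place of 2-fluorophenyl on a double-bonded chain carbon bound to a double-bonded ring carbon. This puts 3-bromophenyl in place of 2-fluorophenyl on a double-bonded chain carbon bound to a double-bonded ring carbon. Going by the values given here, no pair of measured compounds differs in one place only, so no measured step shows how large such a change tends to be in this assay.

Compound 1 already sits at the low end of a very small set, so a modest move towards a higher number seems likelier than a lower one. The expected 1.5-fold higher number from compound 1 to compound 4 (0.17 log units; within the scatter) is small and may well stay within the scatter. For compound 4 the estimated value is 1500 nM, with an expected range of 500 nM to 4500 nM.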

Compound 4, half-maximal inhibitory concentration: 4030 nM
Estimate against measurement, compound 4: 2.7-fold (0.43 log units) below, within the range that was stated.
By their numbers in this assay, from the lowest: compound 1; then compounds 4, 2 and 3 (each within the scatter of the next).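

Going by these compounds alone, this is the first measured step: 3-bromophenyl in place of 2-fluorophenyl on a double-bonded chain carbon bound to a double-bonded ring carbon gives a 4.0-fold higher number from compound 1 to compound 4 (0.60 log units; beyond the scatter) in this assay. The two groups match in heavy-atom count and in having one aromatic ring of carbon only, yet inhibition is weaker with 3-bromophenyl, so at this place in the core of compound 1 the read-out responds to which substituted phenyl is present, not just to the count of atoms. No measurement here explains why the change has this effect.

The step alters both the halogen and its place on the phenyl ring, so 3-fluorophenyl or 2-bromophenyl would be needed to separate the two. From the compounds shown here alone, how an unsubstituted phenyl or an aminophenyl would behave here remains open.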